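Replacing Cyano with Methoxy in Compound 2

The compounds below may be only part of what the source reports. "The series", "measured", "known", "first", "only" and "open" are said of these compounds alone.

- Compound 1 (`COc1cc(CN2c3ccc(O)cc3C(C)=CC2(C)C)cc(OC)c1`): 11000 nM
- Compound 2 (`CC(=O)Oc1ccc2c(c1)C(C)=CC(C)(C)N2Cc1cccc(C#N)c1`): 31000 nM

In an ADME assay on L6 cells (Rattus norvegicus) for cytotoxicity, read by resazurin assay, with a stated time of 70 h (on this read-out lower numbers stand for stronger inhibition and higher numbers for weaker inhibition), compound 2 holds the higher of the two numbers (31000 nM). Compound 1 (11000 nM) lies lower, and the gap between them is beyond the usual scatter.

Compound 3 (`COc1cccc(CN2c3ccc(OC(C)=O)cc3C(C)=CC2(C)C)c1`) has not yet been measured. It departs from compound 2 in one place (methoxy in place of cyano on an aromatic carbon), with methoxy in place of cyano on an aromatic carbon, so that 3-cyanophenyl becomes 3-methoxyphenyl. Among the compounds with values here, no measured pair shows this change alone.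

In this assay a small expected step of a 1.6-fold lower number from compound 2 to compound 3 (0.19 log units; within the scatter) towards a lower number would stay within the scatter, and this expectation rests only on compound 1 with its methoxy groups at 11000 nM and on nothing closer. Compound 3 is estimated at 20000 nM (range 7000 nM to 60000 nM).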

Compound 3, half-maximal inhibitory concentration: 29000 nM
The estimate for compound 3 lay 1.5-fold (0.16 log units) below the measured number, within the range that was stated.
By their numbers in this assay, from the lowest: compound 1; then compounds 3 and 2 (each within the scatter of the next).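

In this assay, within the data shown here, the first matched pair at this position gives a 1.1-fold lower number from compound 2 to compound 3 (0.03 log units; within the scatter) when methoxy takes the place of cyano on the aromatic carbon, so the two groups cannot be told apart here. Among these compounds, on the acetate-bearing core shared by these two compounds, the read-out therefore does not separate 3-cyanophenyl from 3-methoxyphenyl, a point the earlier compounds could not settle because no pair among them showed this change alone. No available evidence bears on the reason for this result.

On these data alone, whether an amine or a carboxylic acid on this aromatic carbon would move the number beyond the scatter remains open. A single pair also leaves open whether the same change would read alike on a different core.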